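A few compounds are considered here, and "the series" means these few. Any claim that something is new, unique, unknown or untested is made for them only; others in the source may bear on it.

Compound 1, with the structure `CCc1ccc(C(=O)/C=C/c2ccc3c(c2)B(O)OC3)cc1`, is one of three compounds tested in an ADME assay on L929 cells (Mus musculus) for cytotoxicity, read by resazurin assay, with a stated time of 72 h (on this read-out lower numbers stand for stronger inhibition and higher numbers for weaker inhibition), and on that read-out compound 1 gives > 10 ug/mL, which is a limit of the assay rather than a measured number. Compound 3, with the structure `O=C(/C=C/c1ccc2c(c1)B(O)OC2)c1ccc(O)c(O)c1`, shares the core of compound 1 and in this assay compound 3 also gives > 10 ug/mL, again a limit and not a number. Compound 2, with the structure `COc1cccc(C(=O)/C=C/c2ccccc2)c1`, lacks that core, and in this assay compound 2 gives a measured value of 5.7 ug/mL. Compound 1 therefore stands at the limit of > 10 ug/mL in this assay, at which 2 of the 3 values shown sit, so its position among the three is known only as a boundary.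

The next compound, compound 4, has the structure `O=C(O)c1ccc(C(=O)/C=C/c2ccc3c(c2)B(O)OC3)cc1`. It differs from compound 1 in a single place: carboxy in place of ethyl on an aromatic carbon.

Going by the values given here, no measured step of this kind is available among the three compounds, so the size of the change from compound 1 to compound 4 cannot be read from a neighbouring pair. Because compound 1 sits at the limit of > 10 ug/mL in this assay, at which 2 of the 3 values shown sit, the step from compound 1 to compound 4 is expected to be a step that the limit leaves unreadable from compound 1 to compound 4, that is, no movement beyond the usual scatter. Compound 4 is expected to give about 15 ug/mL, within a range from 8 ug/mL to 40 ug/mL, and most likely the assay will again report only a limit.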

Compound 4, half-maximal inhibitory concentration: > 10 ug/mL
Compound 4 ended at the assay's limit; the forecaster's own chance of this, stated with the estimate: 75%; the middle value does not contradict the limit.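

Going by these compounds alone, no step from compound 1 to compound 4 can be read, because both stand at a limit of this assay rather than at a measured number: the limit of > 10 ug/mL in this assay, at which 3 of the 4 values shown sit.

The compounds shown leave open how far carboxy in place of ethyl on an aromatic carbon shifts the effect on these cells, if it shifts it at all.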